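The source may hold more compounds than are shown below. What is called first, only, known or untested is meant among the compounds shown, and "the series" means these compounds.

In a functional assay on KB 3-1 cells (Homo sapiens) for cytotoxicity, read by MTT assay, with a stated time of 72 h (a higher number here means a weaker inhibitor, a lower number a stronger inhibitor), compound 1 (`O=C1Nc2ccccc2/C1=N/NC(=S)Nc1ccc(Cl)cc1`) gives 13400 nM, compound 2 (`O=C1Nc2ccccc2/C1=N/NC(=S)Nc1ccc(C(F)(F)F)cc1`) gives 8590 nM and compound 3 (`CCc1ccc(NC(=S)N/N=C2\C(=O)Nc3ccccc32)cc1`) gives 4050 nM, the lowest of the three numbers. Compound 4 (`CC(C)(C)c1ccc(NC(=S)N/N=C2\C(=O)Nc3ccccc32)cc1`) has not yet been measured. It carries tert-butyl in place of ethyl on an aromatic carbon.

Within the data shown here, no measured step swaps ethyl for tert-butyl, so the evidence is indirect. Three steps change the group in that place. The first, a 1.6-fold lower number from compound 1 to compound 2 (0.19 log units; within the scatter), stays within the scatter. The other two, a 3.3-fold lower number from compound 1 to compound 3 (0.52 log units; beyond the scatter) and a 2.1-fold lower number from compound 2 to compound 3 (0.33 log units; beyond the scatter), are modest. Replacing one group with another here has therefore moved the number only a little, and a similarly small move is expected in this assay. The direction cannot be told from these steps. The expected step, a 1.2-fold lower number from compound 3 to compound 4 (0.06 log units; within the scatter), is small and is not expected to exceed the scatter. For compound 4 the estimated value is 3500 nM, with an expected range from 1500 nM to 9000 nM.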

Compound 4, half-maximal inhibitory concentration: 8130 nM
For compound 4 the middle estimate is 2.3-fold (0.37 log units) below the measured one, and the stated range covers the measured number.
By their numbers in this assay, from the lowest: compounds 3, 4, 2 and 1 (each within the scatter of the next, the first and the last beyond it).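

In this assay, among these compounds, the swap of ethyl for tert-butyl, a 2.0-fold higher number from compound 3 to compound 4 (0.30 log units; within the scatter), gives the first direct reading between two alkyl groups at this position, and it does not separate them. Tert-butyl also stays within the scatter of the other two groups, with a 1.1-fold lower number from compound 2 to compound 4 (0.02 log units; within the scatter) and a 1.6-fold lower number from compound 1 to compound 4 (0.22 log units; within the scatter), whereas ethyl stood beyond the scatter from both, so the separation seen for ethyl does not extend to tert-butyl. Nothing available here accounts for these numbers.

The compounds shown leave open whether a group of another kind at this position, such as an amine, a methoxy or a carboxylic acid, would move the number further than these four groups do. They also leave open whether a longer chain, such as butyl, would stay within the same narrow span.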